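Sulfonamide aryl variation in a bicyclic prostanoid acid series

The source may hold more compounds than are shown below. What is called first, only, known or untested is meant among the compounds shown, and "the series" means these compounds.

Measured so far:
compound 1 `O=C(O)CCC/C=C\C[C@H]1[C@@H]2CCC(C2)[C@@H]1NS(=O)(=O)c1ccc([N+](=O)[O-])cc1`: 1400 nM
compound 2 `Cc1ccc(S(=O)(=O)N[C@H]2C3CC[C@H](C3)[C@@H]2C/C=C\CCCC(=O)O)cc1`: 500 nM

Among the measured compounds shown here, in a functional assay (plasma) for inhibition, with Oryctolagus cuniculus as the target (on this read-out lower numbers stand for stronger inhibition and higher numbers for weaker inhibition), compound 2 gives the lowest of the two numbers; the only comparison is a 2.8-fold lower number from compound 1 to compound 2 (0.45 log units; beyond the scatter). Compound 3 `Cc1ccccc1S(=O)(=O)N[C@H]1C2CC[C@H](C2)[C@@H]1C/C=C\CCCC(=O)O` is not yet measured. It differs from compound 2 by 2-methylphenyl in place of 4-methylphenyl on a sulfonyl sulfur. For the measured compounds named here, no measured step moves a substituent around the aromatic ring; the one known step swapped the group itself, so it bears only loosely here. A change of no more than the scatter is therefore expected, with the estimated step being a 1.4-fold higher number from compound 2 to compound 3 (0.15 log units; within the scatter). Compound 3 is estimated at 700 nM, ranging from 250 nM to 2000 nM.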

Compound 3, half-maximal inhibitory concentration: 6200 nM
For compound 3 the middle estimate is 8.9-fold (0.95 log units) below the measured one; the measured number lies above the stated range.
By their numbers in this assay, from the lowest: compound 2; then compound 1; then compound 3.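

In this assay, 2-methylphenyl in place of 4-methylphenyl on a sulfonyl sulfur gives a 12-fold higher number from compound 2 to compound 3 (1.09 log units; beyond the scatter), so with the same atoms the place of the methyl on the aromatic ring counts, not only the identity of the group. 2-Methylphenyl in place of 4-nitrophenyl gives a 4.4-fold higher number from compound 1 to compound 3 (0.65 log units; beyond the scatter), so 2-methylphenyl also gives a higher number than the aryl group of the weaker earlier compound. Nothing on hand accounts for this shift.

Still open, from the compounds shown here alone, is whether the loss is tied to methyl or extends to other groups at this place, such as 2-methoxyphenyl or 2-chlorophenyl. The compounds shown also leave open how unsubstituted phenyl would compare.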